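Halogen Exchange on a Benzothiophene Amide for Urotensin-2 Binding

This account rests on a few compounds, and the source may have more. Where it says the series, first, only, none or still open, it means among the compounds named here.

Compound 1 `O=C(NC1CCN(Cc2ccc(OC3CCNCC3)c(Br)c2)CC1)c1ccco1` gives 770 nM in an assay on HEK293 cells for displacement of a labelled ligand from Urotensin-2 receptor (Homo sapiens), read by fluorescence, with a stated time of 90 min; on this read-out higher numbers stand for weaker inhibition and lower numbers for stronger inhibition.
Compound 2 `O=C(NC1CCN(Cc2ccc(OC3CCNCC3)c(Br)c2)CC1)c1cc2cc(F)ccc2s1` gives 53 nM in this assay.
Compound 3 `O=C(NC1CCN(Cc2ccc(OC3CCNCC3)c(Br)c2)CC1)c1cc2cc(Cl)ccc2s1` has not yet been measured in this assay.

For the measured compounds named here, compound 2 holds the lowest of the two numbers measured so far; its only neighbour, compound 1, stands higher, and the step between them, a 15-fold lower number from compound 1 to compound 2 (1.16 log units; beyond the scatter), replaces the whole ring attached to the carbonyl and lies well beyond the scatter. The move to compound 3 is much smaller in kind: chloro in place of fluoro on an aromatic carbon. Going by the values given here, no measured step bears directly on this exchange of one halogen for another; the single step available, a 15-fold lower number from compound 1 to compound 2 (1.16 log units; beyond the scatter), concerns a change of ring system rather than a substituent on it, so it offers no guide to direction. With the shared core and the amide unchanged, the expected step from compound 2 to compound 3 is a 1.2-fold lower number from compound 2 to compound 3 (0.07 log units; within the scatter), that is, nothing beyond the scatter in either direction. Compound 3 is therefore estimated at 45 nM in this assay, with a range from 18 nM to 120 nM.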

Compound 3, half-maximal inhibitory concentration: 51 nM
Compound 3: the middle estimate sits 1.1-fold (0.05 log units) below what was measured, within the range that was stated.
By their numbers in this assay, from the lowest: compounds 3 and 2 (each within the scatter of the next); then compound 1.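

In this assay, the exchange of fluoro for chloro on this aromatic carbon gives a 1.0-fold lower number from compound 2 to compound 3 (0.02 log units; within the scatter) and so lies within the scatter, which means that the two halogens cannot be ranked at this place. The gain over the furan-2-yl amide also holds with the new halogen: replacing that ring with 5-chloro-1-benzothiophen-2-yl gives a 15-fold lower number from compound 1 to compound 3 (1.18 log units; beyond the scatter), a step of much the same size as the earlier 15-fold lower number from compound 1 to compound 2 (1.16 log units; beyond the scatter), so the lower number does not depend on fluoro alone. The data shown include no further measurement that could explain why the two halogens read alike.

The compounds shown leave open whether the halogen contributes at all, since a benzothiophene amide with plain hydrogen on this carbon is not among them, and two halogens cannot show how far this tolerance extends. A methyl, a methoxy, a nitrile or an amine on the same carbon would test whether groups other than fluoro and chloro also keep the number near that of compound 2 and compound 3.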